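The source may report more compounds than this note shows. Statements on the series, on what has been measured and on what is new or still open speak of the compounds shown alone.

Measured so far in a functional assay on the whole organism for inhibition, with Brassica napus as the target, with a stated time of 72 h, tested at 10 mg/L; a higher number here means more inhibition of growth at the concentration tested, a lower number less inhibition of growth:
compound 1 `COc1cc(C)nc2n/c(=N/C(=O)c3c(-c4ccc(Cl)cc4Cl)noc3C)sn12`: 26.4%
compound 2 `Cc1cc(Cl)nc(NC(=S)NC(=O)c2c(-c3ccc(Cl)cc3Cl)noc2C)n1`: 8.36%

On these two numbers compound 2 stands lowest; compound 1 lies higher by a gap that is beyond the usual scatter, so the two are distinct. Compound 3 `COc1cc(OC)nc(NC(=S)NC(=O)c2c(-c3ccc(Cl)cc3Cl)noc2C)n1` is the next to be tested in this assay. Relative to compound 2 the change is 4,6-dimethoxypyrimidin-2-yl in place of 4-chloro-6-methylpyrimidin-2-yl on an amide-type nitrogen; the rest of the molecule is unchanged. Among the measured compounds shown here, no pair among the measured compounds isolates this exchange, so the direction of the step has no measured anchor. Since compound 2 sits at the low end with 8.36%, the step from compound 2 to compound 3 in this assay is expected to be modest, more likely upward than downward, and it may stay within the scatter. For compound 3 the expected value in this assay is 16%, with a range from 0% to 40%. This corresponds to an expected step of a number 7.6 percentage points higher from compound 2 to compound 3 (within the scatter).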

Compound 3, percent growth inhibition at one concentration: 35.2%
The estimate for compound 3 lay 19.2 percentage points below the measured number; measured number inside the range.
By their numbers in this assay, from the lowest: compound 2; then compounds 1 and 3 (each within the scatter of the next).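

In this assay, among the compounds shown here, 4,6-dimethoxypyrimidin-2-yl in place of 4-chloro-6-methylpyrimidin-2-yl on the amide-type nitrogen gives the first step that can be read, a number 26.8 percentage points higher from compound 2 to compound 3 (beyond the scatter). With the rest of the molecule unchanged, the group on this nitrogen alone is enough to alter growth inhibition at the concentration tested. No measurement at hand bears on why the exchange acts in this direction.

The exchange alters both substituents on the pyrimidine at once, so the step cannot be assigned to the loss of chloro, the loss of methyl or the gain of methoxy. From the compounds shown here alone, the 4-chloro-6-methoxypyrimidin-2-yl and 4,6-dimethylpyrimidin-2-yl groups would help separate these contributions, and it remains open whether the step holds in other species or at other concentrations.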